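Adding a Five-Membered Ring Group to Compound 2

The source may hold more compounds than are shown below. What is called first, only, known or untested is meant among the compounds shown, and "the series" means these compounds.

Among the measured compounds shown here, compound 2 `CC1(C)c2cc(Cl)ccc2C(=O)N1c1cccnc1` gives 108 nM in an assay on cells for inhibition of cytochrome P450 11B2, mitochondrial (Homo sapiens), read by HTRF (a higher number here means a weaker inhibitor, a lower number a stronger inhibitor), the second highest of the three numbers known. Compound 3 `CC1c2cc(Cl)ccc2C(=O)N1c1cccnc1` gives 123 nM; the step of a 1.1-fold higher number from compound 2 to compound 3 (0.06 log units; within the scatter) stays within the scatter. Compound 1 `CC(=O)N1CCN(c2cncc(N3C(=O)c4ccc(Cl)cc4C3(C)C)c2)CC1` gives 9 nM, and the step of a 12-fold higher number from compound 1 to compound 2 (1.08 log units; beyond the scatter) shows that taking away the 4-acetylpiperazin-1-yl group raised the number strongly.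

Compound 4 `CC(=O)N1CC[C@H](Oc2cncc(N3C(=O)c4ccc(Cl)cc4C3(C)C)c2)C1` differs from compound 2 by a group of 9 heavy atoms (6 carbon, 1 nitrogen, 2 oxygen; one five-membered non-aromatic ring with 1 hetero atom) in place of a hydrogen atom, on an aromatic carbon. For the measured compounds named here, the only step that bears on this is the one from compound 1 to compound 2, where a group of similar size at the same place was removed; a change of roughly that size, in the opposite direction, is therefore expected, a 7.2-fold lower number from compound 2 to compound 4 (0.86 log units; beyond the scatter). Compound 4 is estimated at 15 nM, with a range from 5 nM to 50 nM.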

Compound 4, half-maximal inhibitory concentration: 7 nM
Beside the measured number, compound 4's estimate is 2.1-fold (0.33 log units) above it; measured number inside the range.
By their numbers in this assay, from the lowest: compounds 4 and 1 (each within the scatter of the next); then compounds 2 and 3 (each within the scatter of the next).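

In this assay the change gave a 15-fold lower number from compound 2 to compound 4 (1.19 log units; beyond the scatter) and so this aromatic carbon, two atoms from the ring nitrogen, is not tied to the 4-acetylpiperazin-1-yl group: a group with a five-membered non-aromatic ring also lowers the number strongly. Exchanging the six-membered ring group for the five-membered one gave a 1.3-fold lower number from compound 1 to compound 4 (0.11 log units; within the scatter) and that lies within the scatter, so this assay does not separate the two groups. No measurement here explains why either group lowers the number.

From the compounds shown here alone, it remains open whether a much smaller group, such as methoxy or a simple amine, would do the same at this carbon. Going by these compounds, the role of the acetyl group on the ring, and of the opposite arrangement at the defined stereocentre of compound 4, also remains open.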